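Trimming the aryl ring of compound 1 to 4-methylphenyl

This account rests on a few compounds, and the source may have more. Where it says the series, first, only, none or still open, it means among the compounds named here.

Compound 1 `COc1ccc(C2=C(c3ccc(SC)cc3)CC3CCCN3C2=O)cc1C` gives 500 nM in a functional assay on SW-620 cells (Homo sapiens) for cytotoxicity (a higher number here means a weaker inhibitor of growth, a lower number a stronger inhibitor of growth), the higher of the two numbers obtained there; compound 3 `CSc1ccc(C2=C(c3ccc(OCC4CO4)cc3)C(=O)N3CCCC3C2)cc1` gives 90 nM. Compound 2 `CSc1ccc(C2=C(c3ccc(O)cc3)C(=O)N3CCCC3C2)cc1` reaches only the limit > 100000 nM in this assay. Compound 4 `CSc1ccc(C2=C(c3ccc(C)cc3)C(=O)N3CCCC3C2)cc1` differs from compound 1 as follows: 4-methylphenyl in place of 4-methoxy-3-methylphenyl on a double-bonded ring carbon. Among the compounds with values here, two measured steps touch the same aryl ring: an at least 200-fold higher number from compound 1 to compound 2 (2.30 log units; beyond the scatter), and then an at least 1100-fold lower number from compound 2 to compound 3 (3.04 log units; beyond the scatter). Both show this ring driving large swings in either direction, yet neither tests a ring carrying no oxygen at all. A moderate rise in the number is therefore expected for compound 4, a 4.0-fold higher number from compound 1 to compound 4 (0.60 log units; beyond the scatter). Compound 4 is estimated at 2000 nM, likely falling between 300 nM and 20000 nM.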

Compound 4, concentration for 50% growth inhibition: 3000 nM
The estimate for compound 4 lay 1.5-fold (0.18 log units) below the measured number, within the range that was stated.
By their numbers in this assay, from the lowest: compound 3; then compound 1; then compound 4. At a limit, above all of these: compound 2.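

In this assay, an aryl ring carrying no oxygen still inhibits growth, with a 6.0-fold higher number from compound 1 to compound 4 (0.78 log units; beyond the scatter). On the same aromatic carbon, methyl stands well clear of hydroxy, with an at least 33-fold lower number from compound 2 to compound 4 (1.52 log units; beyond the scatter), yet falls short of (oxiran-2-yl)methoxy, with a 33-fold higher number from compound 3 to compound 4 (1.52 log units; beyond the scatter). The step from compound 2 rests on a limit, not a number: the limit of > 100000 nM in this assay, at which 1 of the 4 values shown sits.

From the compounds shown here alone, it remains open whether the oxirane of compound 3 matters or whether a plain propoxy chain would give a similar number. Going by these compounds, how an amine or a carboxylic acid on this aromatic carbon would read also remains open.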